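Pyrazole chain ends: carbamoyl to ester

The compounds below may be only part of what the source reports. "The series", "measured", "known", "first", "only" and "open" are said of these compounds alone.

Measured in a functional assay on NCI-H226 cells (Homo sapiens) for inhibition, read by sulforhodamine B assay, with a stated time of 48 h; on this read-out lower numbers stand for stronger inhibition of growth and higher numbers for weaker inhibition of growth:
- compound 1 `CCCCCCCCCCCC[C@@H](O)[C@H]1CC[C@H]([C@H](O)CCCCCCCCCCN(C)C(=O)c2ccnn2C)O1`: 9770 nM
- compound 2 `CCCCCCCCCCCC[C@@H](O)[C@H]1CC[C@H]([C@H](O)CCCCCCCCCCNCc2ccnn2C)O1`: 3310 nM
- compound 3 `CCCCCCCCCCCC[C@@H](O)[C@H]1CC[C@H]([C@H](O)CCCCCCCCCCC(=O)Nc2ccnn2C)O1`: 75900 nM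

Of the three, compound 3 gives the highest number, 75900 nM, and so the weakest inhibition of growth. The next structure is compound 4 `CCCCCCCCCCCC[C@@H](O)[C@H]1CC[C@H]([C@H](O)CCCCCCCCCCOC(=O)c2ccnn2C)O1`. The change is ((1-methyl-1H-pyrazol-5-yl)carbonyl)oxy in place of (1-methyl-1H-pyrazol-5-yl)carbamoyl on a saturated chain carbon, ten or more bonds along the chain from an oxygen on a saturated carbon and a saturated ring carbon.

No ester has been measured, so the read-across rests on the amide and amine. The (1-methyl-1H-pyrazol-5-yl)carbonyl unit of the entering group also occurs in compound 1, which gives 9770 nM. Going from that unit to the carbamoyl group gave a modest change, a 7.8-fold higher number from compound 1 to compound 3 (0.89 log units; beyond the scatter). The largest change, a 23-fold higher number from compound 2 to compound 3 (1.36 log units; beyond the scatter), ends at the same carbamoyl group, but the amine has no carbonyl and is a weaker guide. A modest step to a lower number is therefore expected in this assay, with a 6.3-fold lower number from compound 3 to compound 4 (0.80 log units; beyond the scatter) as the estimated size. For compound 4 the expected value is 12000 nM, with an estimated range of 3500 nM to 45000 nM.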

Compound 4, concentration for 50% growth inhibition: 28200 nM
Estimate against measurement, compound 4: 2.4-fold (0.37 log units) below, and the stated range covers the measured number.
By their numbers in this assay, from the lowest: compound 2; then compound 1; then compound 4; then compound 3.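

Working notes: in this assay the ((1-methyl-1H-pyrazol-5-yl)carbonyl)oxy end improves on the (1-methyl-1H-pyrazol-5-yl)carbamoyl end, with a 2.7-fold lower number from compound 3 to compound 4 (0.43 log units; beyond the scatter) as the step, so the poorest end so far is not simply matched by every other carbonyl-bearing link at this chain position. The comparison with the methyl amide is the new piece of information: the (1-methyl-1H-pyrazol-5-yl)carbonyl unit stays and only the link to the chain changes, yet a 2.9-fold higher number from compound 1 to compound 4 (0.46 log units; beyond the scatter) is still beyond the scatter, so that unit alone does not set the number. The ester also stays well behind the amine, with an 8.5-fold higher number from compound 2 to compound 4 (0.93 log units; beyond the scatter) as the step, and nothing measured here gives a reason for these differences.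

Open, on these data alone, is whether a tertiary amine, made by placing a methyl on the nitrogen of compound 2, would hold or extend the lead of the amine. Also open, as far as these compounds go, is how a secondary amide with the carbonyl on the pyrazole side, or a longer or shorter chain carrying the amine, would read at this position.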